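Aminothiophene diester imines: aryl variation on the imine carbon

The source may report more compounds than this note shows. Statements on the series, on what has been measured and on what is new or still open speak of the compounds shown alone.

Measured so far in a functional assay on T47D cells (Homo sapiens) for inhibition, read by MTT assay, with a stated time of 48 h; on this read-out higher numbers stand for weaker inhibition and lower numbers for stronger inhibition:
compound 1 `CCOC(=O)c1c(N)sc(/N=C/c2ccc(OC)cc2)c1C(=O)OCC` gives 31900 nM
compound 2 `CCOC(=O)c1c(N)sc(/N=C/c2ccncc2)c1C(=O)OCC` gives 8600 nM
compound 3 `CCOC(=O)c1c(N)sc(/N=C/c2ccc([N+](=O)[O-])cc2)c1C(=O)OCC` gives 2300 nM

Compound 2 sits second highest of the three numbers, with compound 1 above it and compound 3 below it, both separated from it by steps beyond the scatter: a 3.7-fold lower number from compound 1 to compound 2 (0.57 log units; beyond the scatter) and a 3.7-fold lower number from compound 2 to compound 3 (0.57 log units; beyond the scatter). The change to compound 4 `CCOC(=O)c1c(N)sc(/N=C/c2ccc(Br)cc2)c1C(=O)OCC` is 4-bromophenyl in place of pyridin-4-yl on a carbon with a double bond to nitrogen. The two steps that swap the whole aryl group on that carbon, a 3.7-fold lower number from compound 1 to compound 2 (0.57 log units; beyond the scatter) and a 3.7-fold lower number from compound 2 to compound 3 (0.57 log units; beyond the scatter), were each modest, while a 14-fold lower number from compound 1 to compound 3 (1.14 log units; beyond the scatter) was large. Nothing measured shows a bromine-bearing aryl here, so only a modest step, in either direction, or none beyond the scatter is expected for this assay. Compound 4 is therefore estimated at 5000 nM (range 1500 nM to 15000 nM), a step of a 1.7-fold lower number from compound 2 to compound 4 (0.24 log units; within the scatter).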

Compound 4, half-maximal inhibitory concentration: 13200 nM
Compound 4: middle estimate off by 2.6-fold (0.42 log units), on the low side; low and high end bracket the measured number.
By their numbers in this assay, from the lowest: compound 3; then compounds 2 and 4 (each within the scatter of the next); then compound 1.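

Exchanging pyridin-4-yl for 4-bromophenyl on the carbon double-bonded to nitrogen leaves the read-out in this assay unresolved: a 1.5-fold higher number from compound 2 to compound 4 (0.19 log units; within the scatter). Among the substituted phenyl imines, bromo separates from both earlier groups, with a 5.7-fold higher number from compound 3 to compound 4 (0.76 log units; beyond the scatter) and a 2.4-fold lower number from compound 1 to compound 4 (0.38 log units; beyond the scatter), so the aryl substituent matters here, and compound 4 falls between the methoxy and nitro compounds. No available measurement bears on the reason for this order.

Open: how a dimethylamino group or a carboxylic acid on that aryl ring would read, and whether this order survives replacing the ethyl esters with a longer chain.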